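Replacing the benzoyl group of a hydroxamic acid inhibitor

A few compounds are considered here, and "the series" means these few. Any claim that something is new, unique, unknown or untested is made for them only; others in the source may bear on it.

Compound 1 `CC(c1ccc2oc(-c3ccccc3)cc2c1)N(O)C(=O)c1ccccc1`: 4830 nM
Compound 2 `COC(=O)CCCC(=O)N(O)C(C)c1ccc2oc(-c3cc(OC)c(OC)c(OC)c3)cc2c1`: 40 nM

Of the compounds shown here, two have been measured in an assay on RBL cells for inhibition of Polyunsaturated fatty acid 5-lipoxygenase (Rattus norvegicus); a lower number here means a stronger inhibitor, a higher number a weaker inhibitor. Compound 1 gives 4830 nM, the higher of the two numbers. Compound 2 gives 40 nM, a lower number, and the gap between the two lies beyond the scatter. Among the compounds with values here, compound 2 differs from compound 1 in more than one place, so the two values show only that compound 2 is the stronger inhibitor of the pair; which change carries the gain cannot be read from them.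

Compound 3 `CC(c1ccc2oc(-c3ccccc3)cc2c1)N(O)C(=O)CO` is not yet measured. It keeps the core of compound 1 and changes only the group on the carbonyl carbon: hydroxymethyl in place of phenyl on a carbonyl carbon. Within the data shown here, no measured pair shows this change on its own, so the expectation rests on little.

Compound 3 is expected to give 1500 nM in this assay, with a range from 300 nM to 8000 nM. The step from compound 1 is estimated as a 3.2-fold lower number from compound 1 to compound 3 (0.51 log units; beyond the scatter), a modest move toward stronger inhibition, though it may well stay within the scatter.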

Compound 3, half-maximal inhibitory concentration: 700 nM
Estimate against measurement, compound 3: 2.1-fold (0.33 log units) above; measured number inside the range.
By their numbers in this assay, from the lowest: compound 2; then compound 3; then compound 1.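

Within the data shown here, this is the first comparison that changes one place only, so the effect of the group on the carbonyl carbon can now be read directly: in this assay, putting hydroxymethyl in place of phenyl gives a 6.9-fold lower number from compound 1 to compound 3 (0.84 log units; beyond the scatter). The aromatic ring on the carbonyl carbon is therefore not needed for inhibition here, and a much smaller group without a ring does better, with compound 3 at 700 nM. The change removes the ring and also brings in a hydrogen-bond donor and acceptor, and no data here separate these two differences or explain the gain.

Compound 2 differs from compound 3 in more than one place, so neither its methyl ester chain nor its trimethoxy-substituted phenyl ring can yet be credited with its lower number. From the compounds shown here alone, it also remains open whether the hydroxyl oxygen matters, which a plain methyl or a methoxymethyl on the same carbonyl carbon would test, and whether a longer chain such as hydroxyethyl would hold the gain.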